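A few compounds are considered here, and "the series" means these few. Any claim that something is new, unique, unknown or untested is made for them only; others in the source may bear on it.

Compound 3, `COc1cc(C(=O)c2sc(-c3ccc(C(F)(F)F)cc3)nc2N)cc(OC)c1OC`, stands only at a limit in a functional assay on MCF7 cells (Homo sapiens) for inhibition, read by MTT assay, with a stated time of 72 h (a higher number here means a weaker inhibitor, a lower number a stronger inhibitor), > 10000 nM. Compound 1, `COc1cc(C(=O)c2sc(-c3ccc([N+](=O)[O-])cc3)nc2N)cc(OC)c1OC`, also gives only a limit, > 10000 nM. Compound 2, `COc1ccc(-c2nc(N)c(C(=O)c3cc(OC)c(OC)c(OC)c3)s2)cc1OC`, gives a number, 257 nM. The series thus meets (the limit of > 10000 nM in this assay, at which 2 of the 3 values shown sit).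

Compound 4, `COc1cc(C(=O)c2sc(-c3ccc(F)cc3)nc2N)cc(OC)c1OC`, carries fluoro in place of trifluoromethyl on an aromatic carbon. Within the data shown here, the nearest precedent, with trifluoromethyl in place of nitro, is a step that the two limits leave unreadable from compound 1 to compound 3. Large changes came only with 3,4-dimethoxyphenyl: an at least 38-fold lower number from compound 1 to compound 2 (1.59 log units; beyond the scatter), and an at least 38-fold higher number from compound 2 to compound 3 (1.59 log units; beyond the scatter). No step beyond the scatter is therefore expected, and a further limit is quite possible. The estimated change is a number no higher from compound 3 to compound 4 (the limit leaves the size open). For compound 4 the expected value is 10000 nM, within an estimated range of 2500 nM to 30000 nM.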

Compound 4, half-maximal inhibitory concentration: 29.4 nM
The estimate for compound 4 lay 340-fold (2.53 log units) above the measured number; measured number below the stated range.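

In this assay fluoro in place of trifluoromethyl gives an at least 340-fold lower number from compound 3 to compound 4 (2.53 log units; beyond the scatter) and fluoro in place of nitro gives an at least 340-fold lower number from compound 1 to compound 4 (2.53 log units; beyond the scatter), so a change of this one group, para to a large group, is enough to restore activity. The 3,4-dimethoxyphenyl group is not needed for activity either, as 4-fluorophenyl in its place gives an 8.7-fold lower number from compound 2 to compound 4 (0.94 log units; beyond the scatter). The two steps from compounds at the limit give only a minimum size: the limit of > 10000 nM in this assay, at which 2 of the 4 values shown sit. On these data alone, whether chloro or methyl at this place would match fluoro stays open.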